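From ethyl to dimethylamino at the assay limit

A few compounds are considered here, and "the series" means these few. Any claim that something is new, unique, unknown or untested is made for them only; others in the source may bear on it.

Of the compounds shown here, three sharing one core have been measured in a toxicity assay on MDCK cells (Canis lupus familiaris) for cytotoxicity, read by CCK-8 assay, with a stated time of 48 h (a higher number here means that more compound is tolerated, a lower number that less compound is tolerated), so far. Compound 1 (`CCc1ccc(C(=O)NNc2c(Br)cccc2Br)cc1`) gives > 100000 nM as its result, which is a limit of the assay and not a number. Compound 3 (`CCc1ccc(C(=O)NNc2c(Br)cc(Br)cc2Br)cc1`) gives > 100000 nM as its result, and this too is a limit. Compound 3 therefore has no exact value and stands at the limit of > 100000 nM in this assay, at which 2 of the 3 values shown sit, with compound 1. Compound 2 (`CCOc1ccc(C(=O)NNc2c(Br)cc(Br)cc2Br)cc1`) gives 54800 nM as a true number.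

Compound 4 (`CN(C)c1ccc(C(=O)NNc2c(Br)cc(Br)cc2Br)cc1`) has dimethylamino in place of ethyl on an aromatic carbon, para to a large group (dimethylamino in place of ethyl on an aromatic carbon). For the measured compounds named here, two measured steps bear on this only loosely. Bromo in place of hydrogen on an aromatic carbon gave a step that the two limits leave unreadable from compound 1 to compound 3 and so offers no size to carry over. Ethyl in place of ethoxy on an aromatic carbon gave an at least 1.8-fold higher number from compound 2 to compound 3 (0.26 log units; that floor lies within the scatter) and is the closer guide. Going by the values given here, with compound 2 at 54800 nM as the only exact value, a small move towards a lower number is expected, possibly none beyond the scatter. The expected change is an at least 1.4-fold lower number from compound 3 to compound 4 (0.15 log units; that floor lies within the scatter) in this assay on this reading. For compound 4 the estimate is 70000 nM with an expected range from 30000 nM to 100000 nM in all.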

Compound 4, half-maximal cytotoxic concentration: 20300 nM
Estimate against measurement, compound 4: 3.4-fold (0.54 log units) above; the whole stated range lies above it.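

In this assay, the place on the aromatic ring para to a large group turns out to matter for how much compound the cells tolerate: dimethylamino in place of ethyl gives an at least 4.9-fold lower number from compound 3 to compound 4 (0.69 log units; beyond the scatter). Dimethylamino in place of ethoxy at the same place gives a 2.7-fold lower number from compound 2 to compound 4 (0.43 log units; beyond the scatter), and this is the first step in the series that rests on true numbers at both ends and lies beyond the scatter, so the ethyl, ethoxy and dimethylamino groups at this place are not interchangeable in this assay. The step from ethyl can only be given as a floor, and its true size stays unknown, because compound 3 has a limit and not a number: the limit of > 100000 nM in this assay, at which 2 of the 4 values shown sit.

The compounds shown cannot tell whether the lower number goes with the nitrogen of dimethylamino or with the larger group, and a plain amino group or a longer diethylamino group at this place would help separate the two. From the compounds shown here alone, it also remains open whether dimethylamino has a similar effect on the core of compound 1, which carries one bromo fewer.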